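Ester side chain variation on the aminomethyl biaryl pyridylamide series

The compounds below may be only part of what the source reports. "The series", "measured", "known", "first", "only" and "open" are said of these compounds alone.

Measured so far:
compound 1 `CCCCOC(=O)c1cccc(-c2cc(C(=O)Nc3ccncc3)ccc2CN)c1` — 5.5 nM
compound 2 `CCCCCCOC(=O)c1cccc(-c2cc(C(=O)Nc3ccncc3)ccc2CN)c1` — 22 nM

Both compounds share one core and differ only in the chain on the oxygen of the carbonyl group. In an assay on isolated protein for inhibition of Rho-associated protein kinase 2 (Homo sapiens), read by radiometric assay (a higher number here means a weaker inhibitor, a lower number a stronger inhibitor), compound 1 gives 5.5 nM, and compound 2 gives 22 nM. Within the data shown here, the step of a 4.0-fold higher number from compound 1 to compound 2 (0.60 log units; beyond the scatter) is the only step available, and it sets compound 2 at the highest number of the two measured, with compound 1 as its nearest neighbour.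

Compound 3 `NCc1ccc(C(=O)Nc2ccncc2)cc1-c1cccc(C(=O)OCC2CCCCC2)c1` is not yet measured. Relative to compound 2 it shows (cyclohexyl in place of pentyl on a saturated chain carbon bound to an oxygen next to a carbonyl group); cut one bond further out, the difference reads hexyloxycarbonyl to cyclohexylmethoxycarbonyl. Among the measured compounds shown here, no measured step covers a ring in place of a chain at this position. The step from compound 1 to compound 2 bears on it only indirectly, in that it shows the number rising as the chain grows; compound 3 keeps a chain of similar reach but closes it into a ring, so the expectation is a number near compound 2, with the direction open. The estimated step of a 1.1-fold lower number from compound 2 to compound 3 (0.04 log units; within the scatter) is expected to stay within the scatter. For compound 3 the estimate in this assay is 20 nM, expected between 7 nM and 60 nM.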

Compound 3, half-maximal inhibitory concentration: 48 nM
Compound 3: the middle estimate sits 2.4-fold (0.38 log units) below what was measured; the measured number falls inside the stated range.
By their numbers in this assay, from the lowest: compound 1; then compound 2; then compound 3.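

In this assay, cyclohexyl in place of pentyl gives a 2.2-fold higher number from compound 2 to compound 3 (0.34 log units; beyond the scatter) and so shows that, at this position, hexyl to cyclohexylmethyl is not a neutral exchange: a ring here carries a higher number than the open chain of compound 2. Cyclohexyl in place of propyl gives an 8.7-fold higher number from compound 1 to compound 3 (0.94 log units; beyond the scatter) and extends the spread at this position, so that compound 1 holds the lowest number of the three esters and compound 3 the highest, with no compound here going against that order. Nothing available accounts for the gap between the ring and the chains.

The compounds shown leave open whether the number keeps falling with a shorter chain on the oxygen, such as ethyl or methyl, or whether compound 1 already sits near the low end for this position. They also leave open whether a smaller ring such as cyclopropylmethyl, or a chain ending in an amine or a hydroxyl group, would stay nearer compound 1 than cyclohexylmethyl does.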